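The source may hold more compounds than are shown below. What is called first, only, known or untested is meant among the compounds shown, and "the series" means these compounds.

Measured so far in an ADME assay on a cell-free system (plasma, Rattus norvegicus) for metabolic stability, read by LC-MS, with a stated time of 60 min, tested at 100 uM; a lower number here means that less of the compound is left, a higher number that more of the compound is left:
- compound 1 `Cc1c(OCCCCOc2ccc(C(=O)O)cc2F)ccc(C(=O)CC2CCCC2)c1O`: 97%
- compound 2 `Cc1c(OCCCCOc2ccc(F)c(C(=O)O)c2)ccc(C(=O)CC(C)(C)C)c1O`: 83%
- compound 3 `Cc1c(OCCCCOc2ccc(C(=O)CC(C)(C)C)c(O)c2C)cccc1C(=O)O`: 89%

The starting point, compound 2, gives 83%. It lies within the scatter of compound 3, while the gap up to compound 1 lies beyond it. The step under consideration leads to compound 4 `Cc1c(OCCCCOc2ccc(F)c(C(=O)O)c2)ccc(C(=O)C(C)C)c1O`: isopropyl in place of neopentyl on a carbonyl carbon. In words, this is isopropyl in place of neopentyl on a carbonyl carbon whose other neighbours are: aromatic carbon.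

Within the data shown here, only one measured step is available, a number 6 percentage points higher from compound 2 to compound 3 (within the scatter). It replaces 3-carboxy-4-fluorophenyl with 3-carboxy-2-methylphenyl and leaves the group on the carbonyl untouched, so it bears on the new change only indirectly. Compound 1 differs from compound 2 in more than one place, so its value cannot be assigned to the group on the carbonyl alone. Among the measured compounds shown here, no measured pair isolates a change at this place, and the expectation is therefore loose.

On these data alone, with compound 2 as the anchor and the step to compound 3 within the scatter, no shift beyond the scatter is expected, and the direction stays open. The expected change is a number 4 percentage points higher from compound 2 to compound 4 (within the scatter). For compound 4 the estimated value in this assay is 87%, with an expected range from 74% to 100%.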

Compound 4, percent of the compound remaining: 83%
Estimate against measurement, compound 4: 4 percentage points above; measured number inside the range.
By their numbers in this assay, from the lowest: compounds 2, 4, 3 and 1 (each within the scatter of the next, the first and the last beyond it).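

In this assay, among these compounds, the pair compound 2 and compound 4 is the first to isolate the group on the carbonyl carbon, and isopropyl in place of neopentyl gives no change at the digits printed from compound 2 to compound 4 (within the scatter). Among the compounds shown here, the earlier compounds could not show this, as the only earlier step concerned the carboxyphenyl group, and compound 1 differs from compound 2 in more than one place. Here, going from 5 to 3 heavy atoms at this position, both groups without a ring, leaves the two compounds indistinguishable in this read-out, though no measurement available here accounts for that outcome.

This single pair says nothing yet about a methyl, an amine or a longer chain on the carbonyl carbon, nor about whether the same swap would read the same way with 3-carboxy-2-methylphenyl in place of 3-carboxy-4-fluorophenyl. For the compounds shown here, the higher number of compound 1, at 97%, also remains unassigned, as no single-place pair separates the contribution of its ring-bearing group on the carbonyl from that of its different fluorinated carboxyphenyl group.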